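The source may hold more compounds than are shown below. What is called first, only, known or untested is meant among the compounds shown, and "the series" means these compounds.

In a functional assay on HL-60 cells (Homo sapiens) for inhibition, read by MTT assay, with a stated time of 72 h, tested at 30 uM (on this read-out higher numbers stand for more inhibition of growth at the one concentration tested and lower numbers for less inhibition of growth), compound 1 (`C=CCc1ccc(OCc2cn(-c3cccc([N+](=O)[O-])c3)nn2)c(O)c1`) gives 29.8% and compound 2 (`C=CCc1cc(O)c(O)c(CN2CCC(C)CC2)c1`) gives 91.1% as the higher of the two numbers, a gap beyond the scatter. Compound 3 (`C=CCc1cc(O)c(O)c(CN2CCC(CCO)CC2)c1`) differs from compound 2 by a single change (hydroxymethyl in place of hydrogen on a saturated chain carbon bound to a saturated ring carbon), namely hydroxymethyl in place of hydrogen on a saturated chain carbon bound to a saturated ring carbon. For the measured compounds named here, no measured pair shows what this change does. A small fall in this assay is expected, within the scatter. The expected step of a number 7.1 percentage points lower from compound 2 to compound 3 (within the scatter) is therefore modest. For compound 3 the estimate is 84% (expected range 65% to 96%).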

Compound 3, percent growth inhibition at one concentration: 39.4%
The estimate for compound 3 lay 44.6 percentage points above the measured number; measured number below the stated range.
By their numbers in this assay, from the lowest: compounds 1 and 3 (each within the scatter of the next); then compound 2.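

In this assay the change from methyl to 2-hydroxyethyl gives a number 51.7 percentage points lower from compound 2 to compound 3 (beyond the scatter), so a small addition on this saturated chain carbon bound to a saturated ring carbon can cost much of the growth inhibition seen with compound 2. This position is therefore not free to change. Nothing measured here gives a reason for the fall.

The compounds shown leave open whether the added carbon or the oxygen matters more. A plain ethyl or a 2-aminoethyl group at this place would help separate the two.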